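Difluorophenyl Ketone Analogue in a Cytotoxicity Series

The compounds below may be only part of what the source reports. "The series", "measured", "known", "first", "only" and "open" are said of these compounds alone.

In an ADME assay on Vero cells (Chlorocebus sabaeus) for cytotoxicity, read by resazurin assay, with a stated time of 72 h (a higher number here means a weaker inhibitor, a lower number a stronger inhibitor), compound 2 `O=C(CCN1CCN(c2ccc([N+](=O)[O-])cc2)CC1)c1ccc(Br)cc1` gives 79800 nM, the lower of the two numbers available, yet compound 1 `O=C(CCN1CCN(c2ccc(F)cc2)CC1)c1ccc(Br)cc1` with 99500 nM sits within the scatter of it: a 1.2-fold lower number from compound 1 to compound 2 (0.10 log units; within the scatter). Compound 3 `O=C(CCN1CCN(c2ccc([N+](=O)[O-])cc2)CC1)c1ccc(F)c(F)c1` differs from compound 2 by 3,4-difluorophenyl in place of 4-bromophenyl on a carbonyl carbon. Among the measured compounds shown here, the only measured step alters a group elsewhere in the shared core, not the aryl on the carbonyl carbon, so it offers little guidance for this change, and no movement beyond the scatter is expected in this assay. Compound 3 is therefore estimated to give 80000 nM, with a range from 40000 nM to 160000 nM. The expected step is a 1.0-fold higher number from compound 2 to compound 3 (0.00 log units; within the scatter).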

Compound 3, half-maximal inhibitory concentration: 122000 nM
Beside the measured number, compound 3's estimate is 1.5-fold (0.18 log units) below it; low and high end bracket the measured number.
By their numbers in this assay, from the lowest: compounds 2, 1 and 3 (each within the scatter of the next).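

Among the compounds shown here, compound 3 gives the first reading at the aryl group on the carbonyl carbon: in this assay, 3,4-difluorophenyl in place of 4-bromophenyl gives a 1.5-fold higher number from compound 2 to compound 3 (0.18 log units; within the scatter) and stays within the scatter. This position therefore tolerates this exchange of halogen-bearing phenyl groups with no measurable shift in this read-out. Nothing measured here bears on why the number stands where it does.

From the compounds shown here alone, it remains open whether a phenyl group carrying an amine or a carboxylic acid at this position would move the number beyond the scatter. Also open, going by these compounds, is whether the same exchange would behave alike on the core of compound 1.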